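The source may report more compounds than this note shows. Statements on the series, on what has been measured and on what is new or still open speak of the compounds shown alone.

Four compounds built on a shared core were examined in a functional assay on Raji cells (Homo sapiens) for antiproliferative activity, read by CCK-8 assay, with a stated time of 24 h; on this read-out higher numbers stand for weaker inhibition and lower numbers for stronger inhibition. Compound 1 `C=CC(=O)Nc1cccc(Nc2nc(Cl)nc(Nc3ccc(OCCOC)cc3)n2)c1` is part of the set, but in this assay compound 1 gives "not determined" (no result reported), so it contributes no number. Compound 2 `C=CC(=O)Nc1cccc(Nc2ncnc(Nc3ccc(C(=O)Nc4ccc(C)cn4)cc3)n2)c1` gives 125000 nM in this assay. Compound 3 `CC#CC(=O)Nc1cccc(Nc2ncnc(Nc3ccc(C(=O)N4CCCCC4)cc3)n2)c1` gives 4620 nM in this assay, which is the lowest of the two numbers available; its nearest neighbour is compound 2, whose number is considerably higher, and that gap lies beyond the usual scatter of repeated measurements.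

Compound 4 `C=CC(=O)Nc1cccc(Nc2ncnc(Nc3ccc(C(=O)N4CCCCC4)cc3)n2)c1` has not yet been measured. It differs from compound 3 in a single place: vinyl in place of prop-1-yn-1-yl on a carbonyl carbon. Everything else in the two structures is identical.

Among the compounds with values here, no measured pair isolates this particular change, so the expectation rests on the structures and on the one number for compound 3 alone. The replacement is expected to leave compound 4 in roughly the same region as compound 3, with perhaps a slight move towards a lower number, but nothing clearly beyond the scatter. The step of a 1.4-fold lower number from compound 3 to compound 4 (0.16 log units; within the scatter) is the estimated outcome. Compound 4 is therefore expected to give an estimated 3200 nM in this assay, with a likely range from 800 nM to 12000 nM.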

Compound 4, half-maximal inhibitory concentration: 5140 nM
Estimate against measurement, compound 4: 1.6-fold (0.21 log units) below, and the stated range covers the measured number.
By their numbers in this assay, from the lowest: compounds 3 and 4 (each within the scatter of the next); then compound 2.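

In this assay, replacing prop-1-yn-1-yl with vinyl on a carbonyl carbon whose other neighbour is an amide-type nitrogen gives a 1.1-fold higher number from compound 3 to compound 4 (0.05 log units; within the scatter) and so separates neither group from the other while the rest of the structure stays fixed. Within the data shown here, the same compound supplies the first single-place comparison with compound 2: piperidin-1-yl in place of (5-methylpyridin-2-yl)amino on a carbonyl carbon gives a 24-fold lower number from compound 2 to compound 4 (1.39 log units; beyond the scatter) and thus ties a large difference to that one exchange, which the earlier pair, differing in more than one place, could not do. No supporting evidence is available to explain either result.

The compounds shown leave open whether an ethyl group or a longer chain such as but-2-yn-1-yl would also stay close to vinyl and prop-1-yn-1-yl on the first carbonyl carbon. They also leave open how a morpholin-4-yl or dimethylamino group would compare with piperidin-1-yl on the second carbonyl carbon, and whether the vinyl and prop-1-yn-1-yl groups would remain as close with (5-methylpyridin-2-yl)amino in place.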